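Bromo to methyl on the aryl in a weak series

The source may hold more compounds than are shown below. What is called first, only, known or untested is meant among the compounds shown, and "the series" means these compounds.

Measured so far:
compound 1 `CCOC(=O)C1=Cc2ccccc2OC1(OCc1cc(-c2ccc(Br)cc2)no1)C(F)(F)F` — > 150000 nM
compound 2 `CCCCCCCCn1cc(COC2(C(F)(F)F)Oc3ccccc3C=C2C(=O)OCC)nn1` — > 150000 nM
compound 3 `COc1ccc(-c2cc(COC3(C(F)(F)F)Oc4ccccc4C=C3C(=O)O)on2)cc1` — 35200 nM

In a functional assay on MCF7 cells (Homo sapiens) for inhibition, read by MTT assay, with a stated time of 24 h (a higher number here means a weaker inhibitor, a lower number a stronger inhibitor), compound 1 returns > 150000 nM, which is a limit of the measurement and not a number. Compound 2 likewise returns only a limit, > 150000 nM. Within the data shown here, compound 3 is the one compound with an actual number, 35200 nM. Compound 1 therefore stands at the weak end of what has been measured, together with compound 2, and no order between these two can be read; it is weaker than compound 3 only in the sense that it sits at the limit of > 150000 nM in this assay, at which 2 of the 3 values shown sit, while compound 3 does not.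

Compound 4 `CCOC(=O)C1=Cc2ccccc2OC1(OCc1cc(-c2ccc(C)cc2)no1)C(F)(F)F` is not yet measured. It differs from compound 1 in one place: methyl in place of bromo on an aromatic carbon. Among the measured compounds shown here, no measured pair of this kind exists, so the step is estimated to be none beyond the usual scatter, a number no higher from compound 1 to compound 4 (the limit leaves the size open). Compound 4 is expected in this assay at 150000 nM, with a range from 50000 nM to 300000 nM, and most probably it will again be reported only as a limit.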

Compound 4, half-maximal inhibitory concentration: > 150000 nM
Compound 4: a limit, no number; the forecaster's own chance of this, stated with the estimate: 70%; the middle value lies on the limit itself.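

In this assay, compound 1 and compound 4 both return a limit and not a number, so no step can be read between them: the limit of > 150000 nM in this assay, at which 3 of the 4 values shown sit.

The compounds shown leave open what methyl in place of bromo does in this assay, as this change has no pair with two actual numbers.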